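The source may hold more compounds than are shown below. What is called first, only, known or untested is meant among the compounds shown, and "the series" means these compounds.

In a toxicity assay on HCT-116 cells (Homo sapiens) for cytotoxicity, read by MTT assay (on this read-out higher numbers stand for weaker inhibition of growth and lower numbers for stronger inhibition of growth), compound 1 (`C/C(=N\NC(N)=S)c1sc(-c2ccccc2)nc1C`) gives 47.3 ug/mL as a measured number. Compound 2 (`C/C(=N\Nc1nc(-c2ccc(F)cc2)cs1)c1sc(C)nc1C`) gives > 100 ug/mL as a limit of the assay. Compound 3 (`C/C(=N\Nc1nc(-c2ccc(Cl)cc2)cs1)c1sc(C)nc1C`) gives > 100 ug/mL as a limit too, so it stands on no number. Compound 4 (`COc1ccc(-c2csc(N/N=C(\C)c3sc(C)nc3C)n2)cc1`) carries methoxy in place of chloro on an aromatic carbon on the same core, methoxy in place of chloro on an aromatic carbon. Within the data shown here, the one measured step at that place is a step that the two limits leave unreadable from compound 2 to compound 3 and it gives no size to carry over. What remains is the limit of > 100 ug/mL in this assay, at which 2 of the 3 values shown sit, and so no step beyond the scatter is expected, in either direction. The estimated step is a step that the limit leaves unreadable from compound 3 to compound 4 in this assay by this reckoning. For compound 4 the expected value is 110 ug/mL with an estimated range of 45 ug/mL to 250 ug/mL as the likely span.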

Compound 4, concentration for 50% growth inhibition: > 100 ug/mL
Compound 4 gave a limit, no number (the forecaster's own chance of this, stated with the estimate: 65%); the middle value is on the limit's open side.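

Compound 2, compound 3 and compound 4 all stand on limits and not on numbers, so no new step can be read among them: the limit of > 100 ug/mL in this assay, at which 3 of the 4 values shown sit.

The compounds shown leave open how fluoro, chloro and methoxy compare at this place on the shared core.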